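The source may report more compounds than this note shows. Statements on the series, on what has been measured and on what is new or still open speak of the compounds shown alone.

In an ADME assay on microsomes from liver (Homo sapiens) for metabolic stability, read by LC-MS, using NADPH, with stated times of 5 min and 30 min, tested at 1 uM (a lower number here means slower removal, a higher number faster removal of the compound), compound 1 `O=C1CCCN1c1cnc(NCc2c(F)ccc3c2CCO3)c2cn[nH]c(=O)c12` gives 23 mL.min-1.g-1 and compound 2 `Cc1cc(-c2cnc(NCc3c(F)ccc4c3CCO4)c3cn[nH]c(=O)c23)n(C)n1` gives 24 mL.min-1.g-1, which places compound 2 level with compound 1 within the scatter. Compound 3 `CNC(=O)c1ncc(-c2cnc(NCc3c(F)ccc4c3CCO4)c3cn[nH]c(=O)c23)n1C` differs from compound 2 in one place: 1-methyl-2-(methylcarbamoyl)-1H-imidazol-5-yl in place of 1,3-dimethyl-1H-pyrazol-5-yl on an aromatic carbon. Among the measured compounds shown here, only one measured step bears on this site, a 1.0-fold higher number from compound 1 to compound 2 (0.02 log units; within the scatter), and that swap of one group for another stayed within the scatter. One step is a thin guide to a new group, so no shift beyond the scatter is expected, and the estimated change is a 1.3-fold lower number from compound 2 to compound 3 (0.10 log units; within the scatter). Compound 3 is expected at 19 mL.min-1.g-1, within a range of 8 mL.min-1.g-1 to 42 mL.min-1.g-1.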

Compound 3, intrinsic clearance in microsomes: 24 mL.min-1.g-1
Beside the measured number, compound 3's estimate is 1.3-fold (0.10 log units) below it; measured number inside the range.
By their numbers in this assay, from the lowest: compounds 1, 2 and 3 (each within the scatter of the next).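

In this assay, this position has now taken a third, quite different group with no visible effect: there is no change at the digits printed from compound 2 to compound 3 (within the scatter), and a 1.0-fold higher number from compound 1 to compound 3 (0.02 log units; within the scatter). So 1-methyl-2-(methylcarbamoyl)-1H-imidazol-5-yl, with more heavy atoms than 1,3-dimethyl-1H-pyrazol-5-yl and a hydrogen-bond donor that group lacks, is tolerated here without a shift beyond the scatter. No supporting data explain why these groups read alike. On these data alone, whether an amine or a carboxylic acid at this position would shift the number remains open. So does whether changes elsewhere on the shared core would do so.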